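This account rests on a few compounds, and the source may have more. Where it says the series, first, only, none or still open, it means among the compounds named here.

Values measured so far in an ADME assay on microsomes from liver (Rattus norvegicus) for metabolic stability; on this read-out higher numbers stand for fast clearance and lower numbers for slow clearance:

Compound 1 `O=c1[nH]c2cnccc2n1-c1cc(-c2cc(Cl)ccc2F)nc2[nH]ccc12`: 197 mL/min/kg
Compound 2 `Cn1c(=O)n(-c2cc(-c3ccc(F)cc3F)nc3[nH]ccc23)c2ccncc21`: 272 mL/min/kg

Both numbers sit in a narrow band. Compound 2 gives 272 mL/min/kg, and compound 1 gives 197 mL/min/kg, a gap that lies within the usual scatter of repeated measurements, so the two cannot be told apart on this read-out.

The next compound to be tested is compound 3 `Cn1c(=O)n(-c2cc(-c3cc(Cl)ccc3F)nc3[nH]ccc23)c2ccncc21`. It keeps the rest of compound 2 and carries 5-chloro-2-fluorophenyl in place of 2,4-difluorophenyl on an aromatic carbon. Among the compounds with values here, no measured pair isolates this swap, since compound 1 and compound 2 differ in more than one place. Still, compound 1 already carries the entering group and gives 197 mL/min/kg, close to the other measured value, so a large move seems unlikely.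

The expected size of the change, a 1.1-fold lower number from compound 2 to compound 3 (0.05 log units; within the scatter), is small and should stay within the scatter, with no firm direction. In this assay, compound 3 is estimated at 240 mL/min/kg, with an expected range of 120 mL/min/kg to 420 mL/min/kg.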

Compound 3, clearance: 204 mL/min/kg
Estimate against measurement, compound 3: 1.2-fold (0.07 log units) above; the range from low to high includes it.
By their numbers in this assay, from the lowest: compounds 1, 3 and 2 (each within the scatter of the next).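

In this assay, putting 5-chloro-2-fluorophenyl in place of 2,4-difluorophenyl on the aromatic carbon next to the ring nitrogen gives a 1.3-fold lower number from compound 2 to compound 3 (0.12 log units; within the scatter), so this pair, the first to isolate the swap, shows that the two aryl groups cannot be told apart on this read-out. Within the data shown here, the result also isolates a second change for the first time: methyl in place of hydrogen on an aromatic nitrogen gives a 1.0-fold higher number from compound 1 to compound 3 (0.02 log units; within the scatter), so that pair cannot be told apart either, and neither single change moves the clearance number beyond the usual scatter of repeat measurements. Nothing available here gives a reason for these results.

The compounds shown carry only fluorinated, halogen-bearing phenyl groups at this position and only hydrogen or methyl on the aromatic nitrogen, which leaves open whether an amine such as piperidine at the ring carbon, or a longer chain such as propyl on the nitrogen, would give a number clearly apart from this group. They also leave open whether either of these two small changes would stay as small if the other parts of the shared core were different.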